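The source may hold more compounds than are shown below. What is called first, only, known or untested is meant among the compounds shown, and "the series" means these compounds.

Measured so far:
compound 1, `O=C1C2=C(C(=O)c3ncccc31)C1(CS2)NC(=O)N(c2ccc([N+](=O)[O-])cc2)C1=O`: 2 nM
compound 2, `O=C1NN(c2ccc(Cl)cc2)C(=O)C2(CSC3=C2C(=O)c2ncccc2C3=O)N1`: 51 nM

Both were tested in a functional assay on CCRF-SB cells (Homo sapiens) for antiproliferative activity, read by MTT assay, with a stated time of 96 h; on this read-out lower numbers stand for stronger inhibition and higher numbers for weaker inhibition. Compound 1 gives the lowest of the two numbers; compound 2 sits well apart from it, beyond the usual scatter. Compound 3, `CCCCc1ccc(N2C(=O)NC3(CSC4=C3C(=O)c3ncccc3C4=O)C2=O)cc1`, has not yet been measured. It differs from compound 1 in one place: butyl in place of nitro on an aromatic carbon. Among the measured compounds shown here, no measured pair shows this change, so its size is unknown. A modest loss seems the likeliest outcome, and the step from compound 1 to compound 3 is expected to be a 5.0-fold higher number from compound 1 to compound 3 (0.70 log units; beyond the scatter). For compound 3 the estimated result is 10 nM, within a range from 2 nM to 60 nM.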

Compound 3, half-maximal inhibitory concentration: 190 nM
Compound 3: middle estimate off by 19-fold (1.28 log units), on the low side, outside the stated range (above it).
By their numbers in this assay, from the lowest: compound 1; then compound 2; then compound 3.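

Compound 1 and compound 3 show that the group at this place matters greatly: in this assay, the change from 4-nitrophenyl to 4-butylphenyl gives a 95-fold higher number from compound 1 to compound 3 (1.98 log units; beyond the scatter). Nitro carries hydrogen-bond acceptors and butyl carries none, but this count alone does not identify what drives the loss. Nothing available explains the size of this step.

The compounds shown leave open how an amine, a methoxy group or a shorter chain such as methyl would behave at this place. They also leave open whether nitro favours activity, butyl disfavours it, or both.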